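The source may report more compounds than this note shows. Statements on the series, on what has been measured and on what is new or still open speak of the compounds shown alone.

Working notes on the series, read in a functional assay on Huh-7 cells (Homo sapiens) for antiproliferative activity, with a stated time of 48 h; on this read-out lower numbers stand for stronger inhibition and higher numbers for weaker inhibition. Compound 1 (`CCN(CC)c1ccc(-c2cccc(C(F)(F)F)c2)nn1`) gives > 25000 nM, which is a limit and not a number. Going by the values given here, compound 2 (`CN1CCN(c2ccc(-c3cccc(C(F)(F)F)c3)nn2)CC1`) gives 30000 nM, the only true number so far, so its standing against compound 1 cannot be read. Compound 3 (`FC(F)(F)c1cccc(-c2ccc(N3CCCC3)nn2)c1`) is not yet measured.

The change to compound 3 is pyrrolidin-1-yl in place of 4-methylpiperazin-1-yl on an aromatic carbon. The amine group is exchanged on an aromatic carbon, and the rest of the structure stays the same.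

Among the compounds with values here, one measured step bears on this: a step that the limit leaves unreadable from compound 1 to compound 2. It is also an exchange of the amine group on that carbon, and its size cannot be read. For compound 1, the relevant evidence is the limit of > 25000 nM in this assay, at which 1 of the 2 values shown sits. With compound 2 at 30000 nM, the series offers no readable gain from such an exchange, so no step beyond the scatter is expected in this assay, in either direction. The estimated step is a 1.1-fold lower number from compound 2 to compound 3 (0.05 log units; within the scatter). A limit rather than a number is also a real possibility. Compound 3 is expected at 27000 nM, with an estimated range of 12000 nM to 60000 nM.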

Compound 3, half-maximal inhibitory concentration: 30000 nM
Compound 3: middle estimate off by 1.1-fold (0.05 log units), on the low side; the range from low to high includes it.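

Going by these compounds alone, the first readable step at this position in this assay is no change at the digits printed from compound 2 to compound 3 (within the scatter). Pyrrolidin-1-yl, a five-membered non-aromatic ring with 1 hetero atom, and 4-methylpiperazin-1-yl, a six-membered non-aromatic ring with 2 hetero atoms, therefore cannot be told apart in this read-out, so this exchange of one tertiary ring amine for the other, with the rest of the structure unchanged, leaves the number where it was. Compound 1 remains a limit and not a number, so neither step from it can be read: the limit of > 25000 nM in this assay, at which 1 of the 3 values shown sits.

The compounds shown leave open whether any group on this carbon can move the read-out, for instance a morpholine ring, an unsubstituted piperazine carrying a free amine hydrogen, or a longer chain ending in a primary amine. They also leave open whether the read-out depends on the rest of the shared core, for instance with a nitrile or a carboxylic acid in place of trifluoromethyl.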